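Furan-3-yl in Place of 2-Fluoropyridin-4-yl

A few compounds are considered here, and "the series" means these few. Any claim that something is new, unique, unknown or untested is made for them only; others in the source may bear on it.

Compounds measured in an in vitro functional assay on HEK285-7 cells for antagonist activity at prostaglandin D2 receptor 2 (Homo sapiens), read by BRET and beta-arrestin recruitment; on this read-out lower numbers stand for stronger inhibition and higher numbers for weaker inhibition:
compound 1 `Nc1nc(-c2ccc(Cl)cc2)c(CC(=O)O)s1` gives > 100000 nM.
compound 2 `CCC(c1ccccc1)c1nc(-c2ccc(Cl)cc2)c(CC(=O)O)s1` gives > 100000 nM.
compound 3 `O=C(O)Cc1sc(C(c2ccc(F)cc2)c2ccc(F)cc2)nc1-c1ccnc(F)c1` gives 4.7 nM.

For compound 1 the value > 100000 nM is a limit of the assay, not a number. For compound 2 the value > 100000 nM is likewise a limit. Among the measured compounds shown here, compound 3 is therefore the only member of this set with a number in this assay, and it stands apart from the other two because of the limit of > 100000 nM in this assay, at which 2 of the 3 values shown sit. No pair of these compounds differs in a single place, so no measured step can be drawn between them.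

Compound 4 `O=C(O)Cc1sc(C(c2ccc(F)cc2)c2ccc(F)cc2)nc1-c1ccoc1` has not yet been measured. It differs from compound 3 by furan-3-yl in place of 2-fluoropyridin-4-yl on an aromatic carbon. The change keeps the large group and the carboxymethyl group of compound 3 and alters only the ring that sits on the aromatic carbon described. For the measured compounds named here, since no measured step exists for comparison, the expectation rests on compound 3 alone: a small loss is estimated, with a 3.2-fold higher number from compound 3 to compound 4 (0.50 log units; beyond the scatter) lying at the edge of the scatter rather than far beyond it. Compound 4 is expected to give 15 nM in this assay, within a range from 3 nM to 80 nM.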

Compound 4, half-maximal inhibitory concentration: 130 nM
Compound 4: the middle estimate sits 8.7-fold (0.94 log units) below what was measured; the whole stated range lies below it.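

In this assay, this aromatic carbon, next to the ring nitrogen and next to the ring atom that bears a carboxymethyl group, now has its first measured step: a 28-fold higher number from compound 3 to compound 4 (1.44 log units; beyond the scatter). The earlier compounds offered no pair differing in a single place, whereas here the large group and the carboxymethyl group stay fixed, so the exchange of 2-fluoropyridin-4-yl for furan-3-yl alone accounts for the difference, and compound 4 still gives a number, 130 nM, rather than a limit. The change replaces a six-membered aromatic ring bearing fluorine with a five-membered aromatic ring containing oxygen, but the compounds shown give no reason for the size of this step.

The compounds shown do not separate ring size from the loss of the fluorine or of the ring nitrogen; an unsubstituted pyridin-4-yl or a thiophen-3-yl on this carbon would help to tell these apart. As far as these compounds go, whether the step keeps its size when a methyl group stands in place of the large group also remains open.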